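Triazene series, L1210 antiproliferative: compound 3 to compound 4

The source may hold more compounds than are shown below. What is called first, only, known or untested is meant among the compounds shown, and "the series" means these compounds.

Measured values in a functional assay on L1210 cells (Mus musculus) for antiproliferative activity; a lower number here means a less potent compound, a higher number a more potent compound, by a factor of ten per unit of this negative logarithm:
- compound 1 `C/N=N/Nc1ccccc1`: 3.6
- compound 2 `CN(/N=N/c1ccc(C(N)=O)cc1)c1cccs1`: 2.9
- compound 3 `CN(C)/N=N/c1nc(Cc2ccccc2)[nH]c1C(N)=O`: 2.89

Among the three numbers in this assay, compound 3 stands lowest. Its nearest neighbour is compound 2, whose number is higher by an amount within the usual scatter, so no order can be read between compound 2 and compound 3. Its furthest neighbour is compound 1, whose number is higher by an amount beyond the scatter, so compound 1 is more potent than compound 3 in this assay.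

Compound 4 `Cc1nc(/N=N/N(C)C)c(C(N)=O)[nH]1` is not yet measured. It differs from compound 3 in a single place: hydrogen in place of phenyl on a saturated chain carbon bound to an aromatic carbon. Within the data shown here, no step between two measured compounds is available that would show what a change of this kind does in this assay. The working assumption is therefore a small step, or none beyond the scatter, with a slight lean towards a lower number for compound 4.

Compound 4 is expected to give about 2.7 in this assay, with a range from 2.2 to 3.3. That estimate means an expected step of a number 0.19 log units lower from compound 3 to compound 4 (within the scatter).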

Compound 4, logarithm of the reciprocal of the active concentration, log(1/C): 3.06
For compound 4 the middle estimate is 0.36 log units below the measured one; low and high end bracket the measured number.
By their numbers in this assay, from the lowest: compounds 3, 2 and 4 (each within the scatter of the next); then compound 1.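

this assay now shows a number 0.17 log units higher from compound 3 to compound 4 (within the scatter) as the first step between two measured compounds in this series, with hydrogen in place of phenyl on a saturated chain carbon bound to an aromatic carbon. At this place, then, all 6 heavy atoms of the phenyl and its six-membered aromatic ring of carbon only can go without a change that can be told from the scatter, so the number in this read-out does not depend measurably on that phenyl in this pair. No measurement available for these compounds bears on why the phenyl makes no readable difference here.

As far as these compounds go, whether any other group on that saturated chain carbon, such as a longer chain, an amine or a carboxylic acid, would move the number beyond the scatter remains open, since one pair tests only phenyl against hydrogen. Also open, from the compounds shown here alone, is whether the same exchange would stay as silent on another core, as this step comes from the core of compound 3 alone.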